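The source may hold more compounds than are shown below. What is called first, only, known or untested is meant among the compounds shown, and "the series" means these compounds.

Compound 1 `C=C(C)[C@@H]1CC=C(Cn2cc(COc3cccc(C4NC(=O)NC(C)=C4C(=O)OCC)c3)nn2)CC1` and compound 2 `C=C(C)[C@@H]1CC=C(Cn2cc(COc3cc(C4NC(=O)NC(C)=C4C(=O)OCC)ccc3OC)nn2)CC1` share one core, and compound 3 `C=C(C)[C@@H]1CC=C(Cn2cc(COc3cccc(C4NC(=O)NC5=C4C(=O)CC(C)(C)C5)c3)nn2)CC1` and compound 4 `C=C(C)[C@@H]1CC=C(Cn2cc(COc3cc(C4NC(=O)NC5=C4C(=O)CC(C)(C)C5)ccc3OC)nn2)CC1` share another; the difference between the two cores is not broken down here. In a functional assay on OVCAR-3 cells (Homo sapiens) for inhibition, read by sulforhodamine B assay, with a stated time of 48 h (a lower number here means a stronger inhibitor of growth, a higher number a weaker inhibitor of growth), compound 1 gives 18500 nM and compound 2 gives 13500 nM. The change between them is methoxy in place of hydrogen on an aromatic carbon, and it made a 1.4-fold lower number from compound 1 to compound 2 (0.14 log units; within the scatter). Compound 3 reaches only the limit of this assay, giving > 100000 nM, which is a limit of the assay and not a number. Compound 4 carries the same change on the other core: methoxy in place of hydrogen on an aromatic carbon. Since the same change left compound 1 and compound 2 within the scatter of each other, the step from compound 3 to compound 4 is also expected to be small, at a step that the limit leaves unreadable from compound 3 to compound 4. Because compound 3 sits at the limit of > 100000 nM in this assay, at which 1 of the 3 values shown sits, compound 4 is expected to stay at or near that limit, with an estimate of 120000 nM, between 50000 nM and 300000 nM, and the assay may again report only a limit.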

Compound 4, concentration for total growth inhibition: > 100000 nM
Compound 4: no number, only a limit; the forecaster's own chance of this, stated with the estimate: 75%; the middle value does not contradict the limit.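

Compound 3 and compound 4 both sit at the same limit of this assay, which is not a number, so no step can be read between them: the limit of > 100000 nM in this assay, at which 2 of the 4 values shown sit.

The compounds shown leave open whether methoxy in place of hydrogen on an aromatic carbon changes growth inhibition at all on the core of compound 3.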